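Piperazine dithiocarbamate benzamides: nitrogen substituent and HeLa inhibition

A few compounds are considered here, and "the series" means these few. Any claim that something is new, unique, unknown or untested is made for them only; others in the source may bear on it.

Measured so far:
- compound 1, `COc1ccc(N2CCN(C(=S)SCc3ccc(C(=O)Nc4ccccc4N)cc3)CC2)cc1`: 52.3%
- compound 2, `Nc1ccccc1NC(=O)c1ccc(CSC(=S)N2CCN(c3ccc(F)cc3)CC2)cc1`: 64.5%
- compound 3, `CN1CCN(C(=S)SCc2ccc(C(=O)Nc3ccccc3N)cc2)CC1`: 75.7%

All three numbers come from a functional assay on HeLa cells (Homo sapiens) for antiproliferative activity, read by CCK-8 assay, with a stated time of 72 h, tested at 8 uM; a higher number here means a stronger effect of the compound at the concentration tested, a lower number a weaker effect. Compound 3 stands highest of the three; its nearest neighbour is compound 2, and compound 1 lies furthest below it. Both of the steps that reach compound 3 change only the group on the ring nitrogen: a number 23.4 percentage points higher from compound 1 to compound 3 (beyond the scatter) and a number 11.2 percentage points higher from compound 2 to compound 3 (beyond the scatter). The step of a number 12.2 percentage points higher from compound 1 to compound 2 (beyond the scatter) concerns the two aryl-bearing compounds alone.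

Compound 4, `Nc1ccccc1NC(=O)c1ccc(CSC(=S)N2CCN(c3ccccc3F)CC2)cc1`, has not yet been measured in this assay. It differs from compound 3 by 2-fluorophenyl in place of methyl on an amine nitrogen in a ring.

The two steps onto compound 3 both show that taking an aryl group off the ring nitrogen in favour of methyl raised the number; compound 4 goes back the other way, so a downward step is expected, closest in kind to the reverse of the step from compound 2. For compound 4 the expected step is a number 13.7 percentage points lower from compound 3 to compound 4 (beyond the scatter). The estimate for compound 4 is therefore 62%, with a range from 48% to 76%.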

Compound 4, a percentage reported as inhibition, at one concentration (the size of the read-out at that concentration, not a potency): 59.2%
Beside the measured number, compound 4's estimate is 2.8 percentage points above it; low and high end bracket the measured number.
By their numbers in this assay, from the lowest: compounds 1, 4 and 2 (each within the scatter of the next, the first and the last beyond it); then compound 3.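

In this assay the step of a number 16.5 percentage points lower from compound 3 to compound 4 (beyond the scatter); with 2-fluorophenyl, a third aryl group on the amine nitrogen in the ring stands under methyl. Among the aryl groups the picture is less sharp: the steps of a number 5.3 percentage points lower from compound 2 to compound 4 (within the scatter) and a number 6.9 percentage points higher from compound 1 to compound 4 (within the scatter) leave compound 4 not distinguishable from either compound 2 or compound 1, even though those two differ from each other beyond the scatter, so exchanging 4-fluorophenyl for 2-fluorophenyl gives no readable change. No available evidence bears on this result.

The compounds shown leave open whether the higher number of compound 3 is particular to methyl or also holds for ethyl, a longer alkyl chain or an acetyl group on that nitrogen. They also leave open whether a benzyl group there would read with methyl or with the aryl groups.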